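Swapping Methoxy for Chloro in a Sulfonamide Series

The source may hold more compounds than are shown below. What is called first, only, known or untested is meant among the compounds shown, and "the series" means these compounds.

Measured so far in a functional assay on MCF7 cells (Homo sapiens) for antiproliferative activity, read by MTT assay, with a stated time of 72 h; on this read-out higher numbers stand for weaker inhibition and lower numbers for stronger inhibition:
- compound 1 `COc1cccc(N(C)S(=O)(=O)C2CC3OC2C(c2ccc(NC(=O)CCCCCCC(=O)O)cc2)=C3c2ccc(O)cc2)c1`: 39400 nM
- compound 2 `CN(c1ccccc1Cl)S(=O)(=O)C1CC2OC1C(c1ccc(NC(=O)CCCCCCC(=O)O)cc1)=C2c1ccc(O)cc1`: 12800 nM
- compound 3 `CCN(c1ccc(OC)cc1)S(=O)(=O)C1CC2OC1C(c1ccc(NC(=O)CCCCCCC(=O)O)cc1)=C2c1ccc(O)cc1`: 20300 nM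

The number for compound 3 cannot be told apart from either of the other two: a 1.9-fold lower number from compound 1 to compound 3 (0.29 log units; within the scatter) and a 1.6-fold higher number from compound 2 to compound 3 (0.20 log units; within the scatter) both lie within the scatter. Only the gap separating compound 1 and compound 2 goes beyond it.

The next compound, compound 4 `CCN(c1ccc(Cl)cc1)S(=O)(=O)C1CC2OC1C(c1ccc(NC(=O)CCCCCCC(=O)O)cc1)=C2c1ccc(O)cc1`, keeps the ethyl group of compound 3 and makes one change, chloro in place of methoxy on an aromatic carbon.

Among the compounds with values here, no measured pair makes exactly this swap. Within the data shown here, the closest precedent is a 3.1-fold lower number from compound 1 to compound 2 (0.49 log units; beyond the scatter), a modest step in which a chloro-bearing ring also replaces a methoxy-bearing ring, though not on the same ring carbon as here. That precedent suggests a lower number in this assay, but only weakly, since it is a single step and the other two steps stayed within the scatter. The expected change is therefore small, and it may not clear the scatter: a 1.5-fold lower number from compound 3 to compound 4 (0.16 log units; within the scatter). The estimate for compound 4 is 14000 nM, with an expected range of 6500 nM to 30000 nM.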

Compound 4, half-maximal inhibitory concentration: 22100 nM
Compound 4: middle estimate off by 1.6-fold (0.20 log units), on the low side; the range from low to high includes it.
By their numbers in this assay, from the lowest: compounds 2, 3, 4 and 1 (each within the scatter of the next, the first and the last beyond it).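

Chloro in place of methoxy on this aromatic carbon, para to a large group, gives a 1.1-fold higher number from compound 3 to compound 4 (0.04 log units; within the scatter) in this assay and so makes no difference that can be told from scatter, with the ethyl group on the sulfonamide nitrogen held constant. Within the data shown here, this is the first direct reading of the swap, since the earlier chloro-for-methoxy comparison also moved the substituent to a different ring carbon and involved a different ring. Compound 4 carries a chloro group yet stays within the scatter of both neighbours, with a 1.7-fold higher number from compound 2 to compound 4 (0.24 log units; within the scatter) and a 1.8-fold lower number from compound 1 to compound 4 (0.25 log units; within the scatter) as the two steps, although each of these changes more than one feature, so having chloro on the ring does not by itself reproduce the gap between compound 1 and compound 2, and nothing available explains why the swap leaves the number where it is.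

The compounds shown leave open whether a different group on this carbon, such as a nitrile or a trifluoromethyl, would move the number beyond the scatter. They also leave open whether chloro and methoxy would stay equivalent with methyl in place of ethyl on the sulfonamide nitrogen.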